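Methoxy on the benzylidene phenyl of two nitro isomers

The source may hold more compounds than are shown below. What is called first, only, known or untested is meant among the compounds shown, and "the series" means these compounds.

Compound 1 `O=C1/C(=C/c2ccccc2)CCC/C1=C\c1cccc([N+](=O)[O-])c1` and compound 2 `O=C1/C(=C/c2ccccc2)CCC/C1=C\c1ccc([N+](=O)[O-])cc1` are built from the same atoms, joined differently; the difference between the two cores is not broken down here. In a functional assay on L1210 cells (Mus musculus) for cytotoxicity, with a stated time of 48 h (a higher number here means a weaker inhibitor, a lower number a stronger inhibitor), compound 1 gives 9440 nM, and compound 2 gives 9800 nM; the two values lie within the scatter of each other, so no order between them is read. Compound 3 `COc1ccc(/C=C2\CCC/C(=C\c3cccc([N+](=O)[O-])c3)C2=O)cc1` carries on the core of compound 1 the change (methoxy in place of hydrogen on an aromatic carbon), and in this assay compound 3 gives 29500 nM. For the measured compounds named here, the resulting step, a 3.1-fold higher number from compound 1 to compound 3 (0.49 log units; beyond the scatter), is the only measured instance of this change in the set. Compound 4 `COc1ccc(/C=C2\CCC/C(=C\c3ccc([N+](=O)[O-])cc3)C2=O)cc1` carries the same change on the core of compound 2: methoxy in place of hydrogen on an aromatic carbon. The place is the same word for word in both cases, on an aromatic carbon of a six-membered aromatic ring of carbon only, para to a large group, so the change is treated as the same change rather than merely the same kind.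

The expectation for compound 4 rests on that single step and on the near-equal starting values of compound 1 and compound 2. Going by the values given here, a loss of the same size is expected because a 3.1-fold higher number from compound 1 to compound 3 (0.49 log units; beyond the scatter) is the only guide available. The expected step in this assay is a 3.0-fold higher number from compound 2 to compound 4 (0.47 log units; beyond the scatter). Compound 4 is therefore estimated at 29000 nM, with a range from 12000 nM to 65000 nM, the width reflecting that one measured step carries the whole expectation.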

Compound 4, half-maximal inhibitory concentration: 240000 nM
Beside the measured number, compound 4's estimate is 8.3-fold (0.92 log units) below it; measured number outside the range, above it.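

In this assay, methoxy in place of hydrogen on an aromatic carbon gives a higher number on both cores, and the new step is a 24-fold higher number from compound 2 to compound 4 (1.39 log units; beyond the scatter), so the direction carries from one core to the other while the size does not: the same change on two cores in this assay, a 3.1-fold higher number (0.49 log units; beyond the scatter) from compound 1 to compound 3 and a 24-fold higher number (1.39 log units; beyond the scatter) from compound 2 to compound 4, 7.8-fold (0.89 log units) apart, beyond the scatter of two such steps The starting points do not separate the two cores, since compound 1 gives 9440 nM and compound 2 gives 9800 nM, within the scatter of each other, so the unchanged compounds gave no sign that the same change would differ in size between them. For the compounds shown here, with only two cores, this shows that a step measured on one core cannot be carried over to the other at full size, but it gives no reason for the gap and no rule for predicting the step on any further core.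

As far as these compounds go, it remains open whether the gap between the two cores is particular to methoxy or would also appear with another group on the same aromatic carbon, such as a hydroxyl, a chlorine or a dimethylamino group. A carboxylic acid at that place would test the same question with a group of a different kind, again on both cores.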